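The source may hold more compounds than are shown below. What is called first, only, known or untested is meant among the compounds shown, and "the series" means these compounds.

Working notes on the series

Compound 3 `CN(C)c1ccc(CNC(=O)c2nc(Br)c3cccnc3c2N[C@H]2CC[C@H](N)CC2)cc1` gives "not determined" (no result reported) in a functional assay on SK-BR-3 cells (Homo sapiens) for cytotoxicity, read by MTT assay, with a stated time of 72 h (on this read-out higher numbers stand for weaker inhibition and lower numbers for stronger inhibition), so it has no number there; its position in the series can only be placed by its neighbours. Compound 1 `N[C@H]1CC[C@H](Nc2c(C(=O)NCc3ccco3)nc(Br)c3cccnc23)CC1` gives 10000 nM in this assay, and compound 2 `COc1ccc(CNC(=O)c2nc(Br)c3cccnc3c2N[C@H]2CC[C@H](N)CC2)cc1` gives 5000 nM. Going by the values given here, the one measured step, a 2.0-fold lower number from compound 1 to compound 2 (0.30 log units; within the scatter), swaps the ring on the saturated chain carbon bound to the amide-type nitrogen and stays within the scatter; it shows that this part of the shared core tolerates a change of aryl without a clear shift in this assay.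

Compound 4 `N[C@H]1CC[C@H](Nc2c(C(=O)NCc3ccccc3)nc(Br)c3cccnc23)CC1` is compound 3 with hydrogen in place of dimethylamino on an aromatic carbon. Among the compounds with values here, no measured step covers the loss of a dimethylamino group, and compound 3 itself is unmeasured, so the expectation rests on compound 1 and compound 2 alone: both carry other rings at the same place and sit close together, so a phenyl at that position is expected to land in the same region, with no step beyond the scatter foreseen in this assay. Within the data shown here, compound 4 is therefore estimated at 7000 nM, with a range from 2500 nM to 20000 nM in this assay, the range kept wide because the series so far spans only compound 1 and compound 2.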

Compound 4, half-maximal inhibitory concentration: 8000 nM
Compound 4: middle estimate off by 1.1-fold (0.06 log units), on the low side, within the range that was stated.
By their numbers in this assay, from the lowest: compounds 2, 4 and 1 (each within the scatter of the next).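

In this assay the plain benzyl of compound 4 sits with the other two rings: a 1.6-fold higher number from compound 2 to compound 4 (0.20 log units; within the scatter) for hydrogen in place of methoxy on an aromatic carbon, and a 1.3-fold lower number from compound 1 to compound 4 (0.10 log units; within the scatter) for phenyl in place of furan-2-yl. Going by these compounds alone, the first of these adds what the earlier pair could not show: a substituent on the phenyl itself can go with no step that stands out from the scatter, and phenyl, 4-methoxyphenyl and furan-2-yl now cannot be told apart at this position in this assay. Nothing at hand offers an explanation for this flat picture.

Steps to or from compound 3 cannot be read, as it has no number, so what dimethylamino does on this aromatic carbon remains unknown. Also open is whether any change here can move the number beyond the scatter, for example a carboxylic acid on the same aromatic carbon, or a longer chain in place of benzyl, since the compounds shown offer only these three closely grouped rings.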